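The source may hold more compounds than are shown below. What is called first, only, known or untested is meant among the compounds shown, and "the series" means these compounds.

Compound 2 `CC1CCN(C2CCN(S(=O)(=O)c3cccc4ccccc34)CC2)CC1` is the anchor for this step. In an ADME assay on HCT-116 cells (Homo sapiens) for cytotoxicity, read by CellTiter-Glo, with a stated time of 72 h (a higher number here means a weaker inhibitor, a lower number a stronger inhibitor), compound 2 gives > 10000 nM, which is a limit of the assay and not a number. Compound 1 `CC(=O)Nc1ccc(S(=O)(=O)N2CCC(N3CCC(C)CC3)CC2)c2ccccc12`, carrying acetamido on an aromatic carbon, gives in this assay > 10000 nM, again only a limit. Compound 3 `CC1CCN(C2CCN(S(=O)(=O)c3cn(C)c(=O)n(C)c3=O)CC2)CC1` gives in this assay > 10000 nM, also a limit. The step that the two limits leave unreadable from compound 1 to compound 2 cannot be sized, since (the limit of > 10000 nM in this assay, at which 3 of the 3 values shown sit). Compound 4 `CC1CCN(C2CCN(S(=O)(=O)c3ccc(Cl)c4ccccc34)CC2)CC1` differs from compound 2 by chloro in place of hydrogen on an aromatic carbon. For the measured compounds named here, no measured step touches a chloro group, and none of the three values is a number, so for compound 4 the estimated step is a step that the limit leaves unreadable from compound 2 to compound 4, not beyond the scatter. Compound 4 is therefore expected to give 12000 nM in this assay, with a range from 4000 nM to 40000 nM.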

Compound 4, half-maximal inhibitory concentration: > 10000 nM
Compound 4: no number, only a limit (the forecaster's own chance of this, stated with the estimate: 70%); the middle value does not contradict the limit.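

In this assay compound 4 gives > 10000 nM, a limit and not a number. The steps to compound 4 from compound 1 and compound 2 therefore cannot be read: the limit of > 10000 nM in this assay, at which 4 of the 4 values shown sit.

Going by these compounds, whether chloro in place of hydrogen or acetamido changes the cytotoxicity of compound 4 remains open.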